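From 4-ethylbenzyl to 1-(3-ethylphenyl)ethyl at the assay limit

A few compounds are considered here, and "the series" means these few. Any claim that something is new, unique, unknown or untested is made for them only; others in the source may bear on it.

In an ADME assay on HEK293 cells (Homo sapiens) for cytotoxicity, read by resazurin assay, with a stated time of 72 h (a higher number here means that more compound is tolerated, a lower number that less compound is tolerated), compound 1 (`O=C(O)c1ccc(CCOc2c(F)ccc3nc(C(=O)NCc4cccc(C5CC5)c4)[nH]c(=O)c23)cc1`) gives > 20000 nM as a limit and not a number. Compound 2 (`CCc1ccc(CNC(=O)c2nc3ccc(F)c(OCCc4ccc(C(=O)O)cc4)c3c(=O)[nH]2)cc1`) gives > 20000 nM as well, which is again only a limit. The evidence on this series is the limit of > 20000 nM in this assay, at which 2 of the 2 values shown sit, and nothing more. Compound 3 (`CCc1cccc(C(C)NC(=O)c2nc3ccc(F)c(OCCc4ccc(C(=O)O)cc4)c3c(=O)[nH]2)c1`) departs from compound 2 in one place: 1-(3-ethylphenyl)ethyl in place of 4-ethylbenzyl on an amide-type nitrogen with 1-(3-ethylphenyl)ethyl in place of 4-ethylbenzyl on an amide-type nitrogen. For the measured compounds named here, the single measured step is a step that the two limits leave unreadable from compound 1 to compound 2 and so offers no size to carry over. Compound 2 gives > 20000 nM as a limit, and on that basis no step beyond the scatter is expected in this assay in either direction. The expected size is a number no higher from compound 2 to compound 3 (the limit leaves the size open) for this change. For compound 3 the estimated value is 20000 nM with an expected range from 10000 nM to 40000 nM in this measurement.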

Compound 3, half-maximal cytotoxic concentration: > 20000 nM
Compound 3 was reported as a limit; the forecaster's own chance of this, stated with the estimate: 85%; the middle value sits exactly at the limit.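

Compound 1, compound 2 and compound 3 all read only as limits in this assay and so the steps among them cannot be read. The compounds shown leave open how much of any of them is tolerated, and whether the changes on the amide-type nitrogen alter that amount.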